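Fluoro in place of hydrogen on compound 2

This account rests on a few compounds, and the source may have more. Where it says the series, first, only, none or still open, it means among the compounds named here.

In an in vitro ADME assay on microsomes (Homo sapiens) for metabolic stability (on this read-out lower numbers stand for a shorter-lived compound and higher numbers for a longer-lived compound), compound 2 `CCc1nc(NC(CC)CC)cnc1-c1ccc(Cl)cc1Cl` gives 0.467 h. This lies within the scatter of compound 1 `CCC(CC)Nc1nc(OC)c(-c2ccc(Cl)cc2Cl)nc1C` at 0.933 h, while compound 3 `CCc1nc(-c2ccc(Cl)cc2Cl)c(CC)nc1NC(C1CC1)C1CC1` sits lower at 0.183 h, a gap that lies beyond the scatter. Compound 2 therefore stands in the upper part of this small set. Compound 4 `CCc1nc(NC(CC)CC)c(F)nc1-c1ccc(Cl)cc1Cl` differs from compound 2 by one change fluoro in place of hydrogen on an aromatic carbon, next to the ring nitrogen and ortho to a (pentan-3-yl)amino group. For the measured compounds named here, no measured pair differs in one place, so the data give no direct precedent and the expectation stays cautious. The expected step is a 1.3-fold higher number from compound 2 to compound 4 (0.11 log units; within the scatter), a slight rise that stays within the scatter. Compound 4 is estimated at 0.6 h, with an expected range of 0.25 h to 1.4 h.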

Compound 4, half-life: 1.22 h
The estimate for compound 4 lay 2.0-fold (0.31 log units) below the measured number; low and high end bracket the measured number.
By their numbers in this assay, from the lowest: compound 3; then compounds 2, 1 and 4 (each within the scatter of the next, the first and the last beyond it).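

In this assay, for the compounds shown here, fluoro in place of hydrogen on the aromatic carbon ortho to a (pentan-3-yl)amino group gives a 2.6-fold higher number from compound 2 to compound 4 (0.42 log units; beyond the scatter) as the first single-place step. This carbon, next to the ring nitrogen, is thus a position where one change moves the half-life beyond the scatter, though the reading rests on this single pair. Nothing measured here accounts for the rise.

Open, from the compounds shown here alone, is whether a nitrile or a trifluoromethyl group on this carbon moves the half-life the same way. Also open, going by these compounds, is whether fluoro gives a similar step alongside an amine other than the (pentan-3-yl)amino group.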